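A pyridinyl group replaces methoxy on the fused bicyclic core

The compounds below may be only part of what the source reports. "The series", "measured", "known", "first", "only" and "open" are said of these compounds alone.

Of the compounds shown here, three have been measured in a functional assay on HCT-116 cells (Homo sapiens) for antiproliferative activity, read by MTT assay, with a stated time of 68 h; a lower number here means a stronger inhibitor, a higher number a weaker inhibitor. Compound 1 `O=S(=O)(Nc1ccc(F)c(C#Cc2cnc3[nH]ncc3c2)c1F)c1ccccc1F` reaches only a limit of the assay, > 10000 nM, which is the limit of > 10000 nM in this assay, at which 1 of the 3 values shown sits. Compound 2 `O=S(=O)(Nc1ccc(F)c(C#Cc2cnc3ccnn3c2)c1F)c1cccnc1` gives 10000 nM. Compound 3 `COc1n[nH]c2ncc(C#Cc3c(F)ccc(NS(=O)(=O)c4cccnc4)c3F)cc12` gives 1280 nM, the lowest of the two numbers shown, and the nearest value, that of compound 2, lies beyond the scatter of repeat measurements.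

Compound 4 `O=S(=O)(Nc1ccc(F)c(C#Cc2cnc3[nH]nc(-c4ccncc4)c3c2)c1F)c1cccnc1` has not yet been measured. It differs from compound 3 by pyridin-4-yl in place of methoxy on an aromatic carbon. For the measured compounds named here, no measured pair shows a comparable change, so the direction rests on judgement alone. Compound 4 is expected to show a modest step toward a lower number in this assay, a 1.8-fold lower number from compound 3 to compound 4 (0.26 log units; within the scatter), with considerable uncertainty. The estimate for compound 4 is 700 nM, between 150 nM and 3500 nM.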

Compound 4, half-maximal inhibitory concentration: > 10000 nM
Compound 4: no number, only a limit (the forecaster's own chance of this, stated with the estimate: 10%); middle value at least 14-fold (1.15 log units) from the limit.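

For the compounds shown here, on this aromatic carbon of the five-membered ring, pyridin-4-yl in place of methoxy gives an at least 7.8-fold higher number from compound 3 to compound 4 (0.89 log units; beyond the scatter) in this assay, the first change at this position that can be read. The activity of compound 3 therefore does not survive this exchange. Compound 4 yields only a limit, not a number, so the step gives no exact size: the limit of > 10000 nM in this assay, at which 2 of the 4 values shown sit.

On these data alone, how far compound 4 lies past that limit stays open. So does whether an amine, a methyl or an ethoxy group at this carbon would hold the value of compound 3.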